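Swapping Cyclohexyl for Tert-Butyl on a Shared Core

This account rests on a few compounds, and the source may have more. Where it says the series, first, only, none or still open, it means among the compounds named here.

Compound 1 `CCc1nn(CC)c(C2CCN(C(=O)CN3CN(c4ccccc4)C4(CCN(C(=O)c5ccc(C6CCCCC6)cc5)CC4)C3=O)CC2)c1C` is the starting point here, yet in an assay on HEK293 cells for displacement of a labelled ligand from NPC1-like intracellular cholesterol transporter 1 (Homo sapiens) (a higher number here means a weaker inhibitor, a lower number a stronger inhibitor), compound 1 gives "not determined" (no result reported); its result was not reported, so its standing can only be read off its close relatives. Two of them share the same core and were measured. Compound 2 `CCOC(=O)C1CCN(C(=O)CN2CN(c3ccccc3)C3(CCN(C(=O)c4ccc(C5CCCCC5)cc4)CC3)C2=O)CC1` gives 900 nM in this assay, and compound 3 `O=C(CN1CN(c2ccccc2)C2(CCN(C(=O)c3ccc(C4CCCCC4)cc3)CC2)C1=O)N1CCC(CO)CC1` gives 1100 nM. For the measured compounds named here, the one step between them, a 1.2-fold higher number from compound 2 to compound 3 (0.09 log units; within the scatter), changes a group far from the part of the molecule of interest here and moves the number hardly at all.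

Compound 4 `CCc1nn(CC)c(C2CCN(C(=O)CN3CN(c4ccccc4)C4(CCN(C(=O)c5ccc(C(C)(C)C)cc5)CC4)C3=O)CC2)c1C` differs from compound 1 in a single place: tert-butyl in place of cyclohexyl on an aromatic carbon. Going by the values given here, no measured pair in this set alters that same position, so there is no directly comparable step to lean on. What the measured compounds do show is that this core, with its cyclohexyl-bearing end intact, sits around the values of compound 2 and compound 3, and that a change elsewhere left the number within the scatter.

From the compounds shown here alone, on that basis compound 4 is expected to land near the same region, estimated at 1500 nM, with a range from 400 nM to 6000 nM, the width reflecting that the step itself is untested.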

Compound 4, half-maximal inhibitory concentration: 2500 nM
Estimate against measurement, compound 4: 1.7-fold (0.22 log units) below; low and high end bracket the measured number.
By their numbers in this assay, from the lowest: compounds 2 and 3 (each within the scatter of the next); then compound 4.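

No step can be read from compound 1 to compound 4: in this assay compound 1 gives "not determined" (no result reported) and so offers no number to set against compound 4. What replacing cyclohexyl with tert-butyl does to the number on this shared core stays open, and no evidence shown here bears on the result.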